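The source may hold more compounds than are shown below. What is called first, only, known or untested is meant among the compounds shown, and "the series" means these compounds.

Compound 1 `Cc1ccc(S(=O)(=O)c2nc3ccccc3nc2N2CCc3ccccc3C2)cc1` gives 22400 nM in a functional assay on PC-3 cells (Homo sapiens) for cytotoxicity, read by MTT assay, with a stated time of 72 h; a higher number here means a weaker inhibitor, a lower number a stronger inhibitor. Compound 2 `COc1ccc(S(=O)(=O)c2nc3ccccc3nc2N2CCc3ccccc3C2)cc1` gives in this assay only a limit, > 50000 nM. Compound 3 `Cc1ccc(S(=O)(=O)c2nc3ccccc3nc2N2CCCC(O)C2)cc1` gives 5330 nM in this assay.

Two changes connect these compounds. From compound 1 to compound 2 the change is methoxy in place of methyl on an aromatic carbon, and it made an at least 2.2-fold higher number from compound 1 to compound 2 (0.34 log units; beyond the scatter); that step is itself a bound, set by the limit of > 50000 nM in this assay, at which 1 of the 3 values shown sits. The two cores differ as counted in 3-hydroxypiperidin-1-yl in place of 1,2,3,4-tetrahydroisoquinolin-2-yl on an aromatic carbon, with a 4.2-fold lower number from compound 1 to compound 3 (0.62 log units; beyond the scatter). Compound 4 `COc1ccc(S(=O)(=O)c2nc3ccccc3nc2N2CCCC(O)C2)cc1` has not yet been measured in this assay. It differs from compound 3 by methoxy in place of methyl on an aromatic carbon, the same change that turned compound 1 into compound 2, at a place described in the same words. For compound 4 the expected step is a 2.8-fold higher number from compound 3 to compound 4 (0.45 log units; beyond the scatter), which rests on an at least 2.2-fold higher number from compound 1 to compound 2 (0.34 log units; beyond the scatter). Compound 4 is therefore estimated at 15000 nM, expected to lie between 7000 nM and 40000 nM.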

Compound 4, half-maximal inhibitory concentration: 3410 nM
Beside the measured number, compound 4's estimate is 4.4-fold (0.64 log units) above it; the whole stated range lies above it.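

In this assay, methoxy in place of methyl now gave a 1.6-fold lower number from compound 3 to compound 4 (0.19 log units; within the scatter), so this change does not carry from one core to the other as a fixed step: the same change on two cores in this assay, an at least 2.2-fold higher number (0.34 log units; beyond the scatter) from compound 1 to compound 2 and a 1.6-fold lower number (0.19 log units; within the scatter) from compound 3 to compound 4, at least 3.4-fold (0.54 log units) apart, beyond the scatter of two such steps. Read the other way, the swap of 1,2,3,4-tetrahydroisoquinolin-2-yl for 3-hydroxypiperidin-1-yl gave an at least 14-fold lower number from compound 2 to compound 4 (1.16 log units; beyond the scatter), which also differs from the earlier step: the same change on two cores in this assay, a 4.2-fold lower number (0.62 log units; beyond the scatter) from compound 1 to compound 3 and an at least 14-fold lower number (1.16 log units; beyond the scatter) from compound 2 to compound 4, at least 3.4-fold (0.54 log units) apart, beyond the scatter of two such steps. For the compounds shown here, the comparison rests on only two cores and does not show why the steps differ, and the size of the gap stays open since compound 2 gives only a limit: the limit of > 50000 nM in this assay, at which 1 of the 4 values shown sits.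

The compounds shown leave open how the methoxy change would behave with an open-chain amine on the shared core. They also leave open what a chlorine or a carboxylic acid on that aromatic ring would do.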